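Replacing pyridin-4-yl with 1-(methylsulfonyl)piperidin-4-yl

The compounds below may be only part of what the source reports. "The series", "measured", "known", "first", "only" and "open" are said of these compounds alone.

Measured so far:
- compound 1 `COCC1CCN(c2nccnc2OC2CN(c3ccc4ccccc4n3)C2)CC1` gives 53000 nM
- compound 2 `N#CC1CCN(c2nccnc2OC2CN(c3ccc4ccccc4n3)C2)CC1` gives 66000 nM
- compound 3 `c1ccc2nc(N3CC(Oc4nccnc4-c4ccncc4)C3)ccc2c1` gives 56000 nM

In a physicochemical assay for solubility, in phosphate buffer, at pH 7.4 (a higher number here means a more soluble compound, a lower number a less soluble compound), compound 3 stands within the scatter of both compound 1 and compound 2, so the three values cannot be ranked. Compound 4 `CS(=O)(=O)N1CCC(c2nccnc2OC2CN(c3ccc4ccccc4n3)C2)CC1` is the next case, with this change: 1-(methylsulfonyl)piperidin-4-yl in place of pyridin-4-yl on an aromatic carbon. Two measured steps exchange a saturated ring and pyridin-4-yl on an aromatic carbon: a 1.1-fold higher number from compound 1 to compound 3 (0.02 log units; within the scatter) and a 1.2-fold lower number from compound 2 to compound 3 (0.07 log units; within the scatter). Both are within the scatter, but neither tests 1-(methylsulfonyl)piperidin-4-yl, so the range stays wide. The expected result in this assay is a 1.2-fold lower number from compound 3 to compound 4 (0.09 log units; within the scatter), and no step beyond the scatter is expected. The estimate for compound 4 is 45000 nM with an expected range from 18000 nM to 90000 nM.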

Compound 4, solubility: 181000 nM
Compound 4: middle estimate off by 4.0-fold (0.60 log units), on the low side, and the stated range ends below it.
By their numbers in this assay, from the lowest: compounds 1, 3 and 2 (each within the scatter of the next); then compound 4.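

In this assay, within the data shown here, 1-(methylsulfonyl)piperidin-4-yl is the first group on this aromatic carbon, next to the ring nitrogen, to give steps beyond the scatter: a 3.2-fold higher number from compound 3 to compound 4 (0.51 log units; beyond the scatter) and a 2.7-fold higher number from compound 2 to compound 4 (0.44 log units; beyond the scatter) and a 3.4-fold higher number from compound 1 to compound 4 (0.53 log units; beyond the scatter). Pyridin-4-yl, 4-cyanopiperidin-1-yl and 4-(methoxymethyl)piperidin-1-yl lie within the scatter of one another, so only this change shows that the position can move the read-out. Nothing available accounts for this result.

From the compounds shown here alone, whether the step belongs to the methylsulfonyl group or to the ring carrying it stays open. A plain piperidin-4-yl or an acetyl group in place of methylsulfonyl would separate the two.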